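The compounds below may be only part of what the source reports. "The series", "measured", "known", "first", "only" and "open" are said of these compounds alone.

Of the compounds shown here, three of one shared core have been measured in a functional assay on PC-3 cells (Homo sapiens) for cytotoxicity, read by MTT assay, with a stated time of 72 h; on this read-out higher numbers stand for weaker inhibition and lower numbers for stronger inhibition. Compound 1, `Cc1cc(=O)n(-c2cccc(F)c2)nc1C(=O)Nc1ccc(Oc2ncnc3c2ccn3C)cc1`, gives only a limit in this assay, > 60000 nM, so its true number is not known (the limit of > 60000 nM in this assay, at which 1 of the 3 values shown sits). Compound 2, `Cc1cc(=O)n(-c2ccccc2Cl)nc1C(=O)Nc1ccc(Oc2ncnc3c2ccn3C)cc1`, gives 16400 nM in this assay, which is an at least 3.6-fold lower number from compound 1 to compound 2 (0.56 log units; beyond the scatter). Compound 3, `Cc1cc(=O)n(-c2cccc(F)c2)nc1C(=O)Nc1ccc(Oc2ncnc3c2ccn3C)c(F)c1`, gives 8990 nM in this assay, which is an at least 6.6-fold lower number from compound 1 to compound 3 (0.82 log units; beyond the scatter). Compound 3 thus has the lowest number among the measured compounds, though its gap to compound 2 lies within the scatter of repeated measurements, so the two cannot be ordered with confidence.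

Compound 4, `Cc1cc(=O)n(-c2ccccc2Cl)nc1C(=O)Nc1ccc(Oc2ncnc3c2ccn3C)c(F)c1`, has not yet been measured. It differs from compound 3 by one change: 2-chlorophenyl in place of 3-fluorophenyl on an aromatic nitrogen. Going by these compounds, the same exchange has been seen once already, from compound 1 to compound 2, where it gave an at least 3.6-fold lower number from compound 1 to compound 2 (0.56 log units; beyond the scatter); since that step started from a limit, its full size is unknown. The expectation for compound 4 is therefore a number no higher than that of compound 3, and possibly somewhat lower, giving an estimated step of a 1.8-fold lower number from compound 3 to compound 4 (0.25 log units; within the scatter) in this assay. Compound 4 is expected to give about 5000 nM, within a range of 1500 nM to 15000 nM.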

Compound 4, half-maximal inhibitory concentration: > 60000 nM
Compound 4 was reported as a limit (the forecaster's own chance of this, stated with the estimate: 3%); middle value at least 12-fold (1.07 log units) away from the limit.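

The exchange of 3-fluorophenyl for 2-chlorophenyl on the aromatic nitrogen has no fixed effect in this assay: with the added fluoro present it gives an at least 6.6-fold higher number from compound 3 to compound 4 (0.82 log units; beyond the scatter), reversing the direction seen without that fluoro: the same change on two cores in this assay, an at least 3.6-fold lower number (0.56 log units; beyond the scatter) from compound 1 to compound 2 and an at least 6.6-fold higher number (0.82 log units; beyond the scatter) from compound 3 to compound 4, at least 24-fold (1.38 log units) apart, beyond the scatter of two such steps

The added fluoro reverses in the same way, giving an at least 3.6-fold higher number from compound 2 to compound 4 (0.56 log units; beyond the scatter) once the 2-chlorophenyl is present: the same change on two cores in this assay, an at least 6.6-fold lower number (0.82 log units; beyond the scatter) from compound 1 to compound 3 and an at least 3.6-fold higher number (0.56 log units; beyond the scatter) from compound 2 to compound 4, at least 24-fold (1.38 log units) apart, beyond the scatter of two such steps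

Going by these compounds, each change therefore lowers the number only where the other is absent, and the full size of both new steps is unknown, compound 4 being a limit.

The compounds shown do not tell why the two changes fail together. On these data alone, it also stays open whether the reversal is particular to these two halogen groups, or would also appear with a methoxy group or an amine on the same aromatic carbon as the added fluoro.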